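Swapping the hydrazone aryl group once more

A few compounds are considered here, and "the series" means these few. Any claim that something is new, unique, unknown or untested is made for them only; others in the source may bear on it.

Two compounds share one core and differ only in the aromatic ring attached to a carbon with a double bond to nitrogen. Compound 1 `O=C(CSc1nnc(-c2ccncc2)n1-c1ccccc1)N/N=C/c1ccc(Cl)cc1` carries a 4-chlorophenyl there; in a functional assay on HCT-116 cells (Homo sapiens) for inhibition, read by MTT assay, with a stated time of 48 h (a lower number here means a stronger inhibitor, a higher number a weaker inhibitor), compound 1 gives 5740 nM. Compound 2 `O=C(CSc1nnc(-c2ccncc2)n1-c1ccccc1)N/N=C/c1cc(Br)cc(Br)c1O` carries a 3,5-dibromo-2-hydroxyphenyl instead, and in this assay compound 2 gives 4500 nM. That is the smaller of the two numbers, but the change from compound 1 to compound 2 a 1.3-fold lower number from compound 1 to compound 2 (0.11 log units; within the scatter), so the two compounds stand together within the scatter.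

Compound 3 `O=C(CSc1nnc(-c2ccncc2)n1-c1ccccc1)N/N=C/c1ccc(O)c(O)c1` makes another exchange at the same place: 3,4-dihydroxyphenyl in place of 3,5-dibromo-2-hydroxyphenyl on a carbon with a double bond to nitrogen. Within the data shown here, the only measured step that bears on this is the one from compound 1 to compound 2, which also swapped the aryl ring on that carbon and stayed within the scatter. Among the measured compounds shown here, with that single step as the only guide, compound 3 is expected to show no change beyond the scatter, a 1.1-fold higher number from compound 2 to compound 3 (0.05 log units; within the scatter). The estimate for compound 3 in this assay is therefore 5000 nM, with a likely range from 2000 nM to 13000 nM.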

Compound 3, half-maximal inhibitory concentration: 14700 nM
For compound 3 the middle estimate is 2.9-fold (0.47 log units) below the measured one, outside the stated range (above it).
By their numbers in this assay, from the lowest: compounds 2 and 1 (each within the scatter of the next); then compound 3.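

The earlier pair suggested that the aryl ring on this carbon could be exchanged with little consequence, but in this assay the 3,4-dihydroxyphenyl ring gives a 3.3-fold higher number from compound 2 to compound 3 (0.51 log units; beyond the scatter) and also a 2.6-fold higher number from compound 1 to compound 3 (0.41 log units; beyond the scatter), so this position does respond to the choice of ring, if only modestly. The two rings that carry halogen, 4-chlorophenyl and 3,5-dibromo-2-hydroxyphenyl, stand together within the scatter, while the one ring with no halogen and two hydroxyl groups gives the highest number of the three, a pattern that rests on these compounds alone. Nothing shown here explains why the number rises with this ring.

Since the step to compound 3 removes halogen and adds a second hydroxyl group in a single exchange, the compounds shown cannot separate the effect of one change from the other. A ring bearing a single hydroxyl group and no halogen would help to pull the two apart, and a ring carrying an amine or a carboxylic acid would show how this position responds to quite different groups.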